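The compounds below may be only part of what the source reports. "The series", "measured", "known", "first", "only" and "open" are said of these compounds alone.

Three amides on one shared core, compound 1 `COc1cc2ncnc(Nc3ccc(NC(=O)c4ccc(C(C)(C)C)cc4)cc3)c2cc1OC`, compound 2 `COc1cc2ncnc(Nc3ccc(NC(=O)c4ccc(Cl)cc4)cc3)c2cc1OC` and compound 3 `COc1cc2ncnc(Nc3ccc(NC(=O)c4ccc(I)cc4)cc3)c2cc1OC`, were tested in a functional assay on MCF7 cells (Homo sapiens) for inhibition, read by MTT assay; a lower number here means a stronger inhibitor, a higher number a weaker inhibitor. Compound 1 gives > 100000 nM, which is a limit of the assay and not a number. Compound 2 gives 30000 nM and compound 3 gives 48000 nM. Compound 3 therefore stands level with its nearest neighbour, as the measured step shows: a 1.6-fold higher number from compound 2 to compound 3 (0.20 log units; within the scatter). Against the limit, the other two steps are an at least 3.3-fold lower number from compound 1 to compound 2 (0.52 log units; beyond the scatter) and an at least 2.0-fold lower number from compound 1 to compound 3 (0.31 log units; beyond the scatter).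

Compound 4 `COc1cc2ncnc(Nc3ccc(NC(=O)c4ccc(Cl)c(Cl)c4)cc3)c2cc1OC` differs from compound 3 as follows: 3,4-dichlorophenyl in place of 4-iodophenyl on a carbonyl carbon. The chloro and iodo step is the closest guide, and it stayed within the scatter, so no clear change is expected in this assay. The expected step is a 1.4-fold lower number from compound 3 to compound 4 (0.14 log units; within the scatter). For compound 4 the estimated value is 35000 nM, within an expected range of 14000 nM to 85000 nM.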

Compound 4, half-maximal inhibitory concentration: 25000 nM
Compound 4: middle estimate off by 1.4-fold (0.15 log units), on the high side; measured number inside the range.
By their numbers in this assay, from the lowest: compounds 4, 2 and 3 (each within the scatter of the next). At a limit, above all of these: compound 1.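

A second chloro on the aromatic ring brings no clear change: a 1.2-fold lower number from compound 2 to compound 4 (0.08 log units; within the scatter). Within the data shown here, replacing 4-iodophenyl with 3,4-dichlorophenyl also stays within the scatter, as a 1.9-fold lower number from compound 3 to compound 4 (0.28 log units; within the scatter) shows, so only the step from 4-(tert-butyl)phenyl stands out, with an at least 4.0-fold lower number from compound 1 to compound 4 (0.60 log units; beyond the scatter). That step starts from compound 1, whose value is a limit and not a number: the limit of > 100000 nM in this assay, at which 1 of the 4 values shown sits. On these data alone, it remains open whether an amine or a carboxylic acid on this aromatic ring would move the number beyond the scatter of compound 2, compound 3 and compound 4.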